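The source may report more compounds than this note shows. Statements on the series, on what has been measured and on what is new or still open speak of the compounds shown alone.

Measured compounds:
Compound 1 `Cc1cccc(NC(=O)CSC(=S)N[C@H]2CCOC2=O)c1C` — "not determined" (no result reported) in a functional assay on MGC-803 cells (Homo sapiens) for cytotoxicity, read by MTT assay, with a stated time of 72 h; on this read-out lower numbers stand for stronger inhibition and higher numbers for weaker inhibition.
Compound 2 `O=C(CSC(=S)N[C@H]1CCOC1=O)Nc1ccccc1` — 39700 nM.
Compound 3 `O=C(CSC(=S)N[C@H]1CCOC1=O)Nc1cccc(C(F)(F)F)c1` — 17900 nM.

Compound 2 stands highest of the two numbers in this assay; its nearest neighbour is compound 3, which sits a step away given by a 2.2-fold lower number from compound 2 to compound 3 (0.35 log units; beyond the scatter), and compound 1 adds no number. The step now followed leads from compound 2 to compound 4 `O=C(CSC(=S)N[C@H]1CCOC1=O)Nc1ccc(C(=O)/C=C/c2ccccc2)cc1`, and the change is (2-phenylethenyl)carbonyl in place of hydrogen on an aromatic carbon. For the measured compounds named here, the only measured step that bears on it is the one from compound 2 to compound 3, where trifluoromethyl in place of hydrogen on an aromatic carbon gave a 2.2-fold lower number from compound 2 to compound 3 (0.35 log units; beyond the scatter), a modest shift beyond the scatter. Going by the values given here, that step shows a substituent on the same ring can lower the number, but no measured compound carries anything as large as (2-phenylethenyl)carbonyl, so the size of the step in this assay is uncertain. On this basis a lowering is expected, probably larger than the trifluoromethyl step, and the step from compound 2 to compound 4 is estimated at a 4.0-fold lower number from compound 2 to compound 4 (0.60 log units; beyond the scatter). Compound 4 is therefore estimated to give 10000 nM in this assay, with a range from 3000 nM to 40000 nM.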

Compound 4, half-maximal inhibitory concentration: 24800 nM
Compound 4: the middle estimate sits 2.5-fold (0.39 log units) below what was measured, within the range that was stated.
By their numbers in this assay, from the lowest: compounds 3, 4 and 2 (each within the scatter of the next, the first and the last beyond it).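

In this assay, placing (2-phenylethenyl)carbonyl on an aromatic carbon, para to a large group, gives a 1.6-fold lower number from compound 2 to compound 4 (0.20 log units; within the scatter), so this group of 10 heavy atoms, with its own six-membered aromatic ring, does not move the number beyond the usual variation between repeated measurements. The earlier compounds shown here offered only the trifluoromethyl step, a 2.2-fold lower number from compound 2 to compound 3 (0.35 log units; beyond the scatter), and the new result shows that a substituent on this ring need not produce a shift beyond the scatter, and that a much larger group does not bring a larger step here. No available evidence accounts for this outcome.

The compounds shown leave open whether a smaller group in the same place, such as an acetyl group, an amine or a carboxylic acid, would lower the number beyond the scatter. They also leave open whether the double bond of the (2-phenylethenyl)carbonyl group matters, which a saturated 3-phenylpropanoyl chain in its place could test, and whether any group on this ring can bring a step larger than the trifluoromethyl one.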